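This account rests on a few compounds, and the source may have more. Where it says the series, first, only, none or still open, it means among the compounds named here.

Measured so far in an ADME assay on RAW264.7 cells (Mus musculus) for cytotoxicity, read by MTT assay, with a stated time of 48 h; on this read-out higher numbers stand for weaker inhibition and lower numbers for stronger inhibition:

compound 1, `CCS(=O)(=O)Nc1ccc(NC(=O)c2ccc(Cl)cc2)cc1C`, 68700 nM
compound 2, `CCS(=O)(=O)Nc1ccc(NC(=O)c2ccc(C#N)cc2)cc1C`, 109000 nM
compound 3, `CS(=O)(=O)Nc1ccc(NC(=O)c2ccc(Cl)cc2)cc1Cl`, 79900 nM

The three measured compounds sit close together in this assay. Compound 1 and compound 2 share a core and differ by cyano in place of chloro on an aromatic carbon; this change gave a 1.6-fold higher number from compound 1 to compound 2 (0.20 log units; within the scatter). Compound 3 stands nearest to compound 1, and its gap to compound 2 is also within the scatter, so no order among the three can be read from these numbers. The difference between the core of compound 3 and the core of compound 1 is not broken down here.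

Compound 4, `CS(=O)(=O)Nc1ccc(NC(=O)c2ccc(C#N)cc2)cc1Cl`, has not yet been measured. It differs from compound 3 by cyano in place of chloro on an aromatic carbon, the same change that was made from compound 1 to compound 2. Within the data shown here, the only guide to its size is that earlier step, which stayed within the scatter. Compound 4 is therefore expected to give a number close to that of compound 3, with an estimated step of a 1.4-fold higher number from compound 3 to compound 4 (0.14 log units; within the scatter). The estimate for compound 4 in this assay is 110000 nM, with a range of 60000 nM to 200000 nM.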

Compound 4, half-maximal inhibitory concentration: > 250000 nM
Compound 4 ended at the assay's limit; the forecaster's own chance of this, stated with the estimate: 20%; at least 2.2-fold (0.35 log units) between middle value and limit.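

Compound 4 gives > 250000 nM in this assay and that value is a limit of the assay, not a number. Cyano in place of chloro gave an at least 3.1-fold higher number from compound 3 to compound 4 (0.49 log units; beyond the scatter) and so passed beyond the scatter, which the same change on the core of compound 1 did not do. This shows that the change can carry over to another core in this series with a step beyond the scatter, but it does not show that the core alters the size of the step, because one of the two steps is known only as a bound: the same change on two cores in this assay, a 1.6-fold higher number (0.20 log units; within the scatter) from compound 1 to compound 2 and an at least 3.1-fold higher number (0.49 log units; beyond the scatter) from compound 3 to compound 4; the limit leaves it open whether they differ.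

The compounds shown carry only chloro and cyano on this aromatic carbon, so it stays open how another group there, such as an amine or a carboxylic acid, would compare on either core. From the compounds shown here alone, it also stays open which difference between the two cores, if any, matters for this step.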